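The source may hold more compounds than are shown below. What is called first, only, known or untested is meant among the compounds shown, and "the series" means these compounds.

Measured so far:
compound 1 `CC(=O)OC[C@H]1O[C@@H](n2cc(CN3C(=O)/C(=C\c4ccccc4)c4ccccc43)nn2)[C@H](OC(C)=O)[C@@H](OC(C)=O)[C@@H]1OC(C)=O`: 33300 nM
compound 2 `CC(=O)OC[C@H]1O[C@@H](n2cc(CN3C(=O)/C(=C\c4ccc(C)cc4)c4ccccc43)nn2)[C@H](OC(C)=O)[C@@H](OC(C)=O)[C@@H]1OC(C)=O`: > 100000 nM

In a functional assay on HeLa cells (Homo sapiens) for cytotoxicity, read by sulforhodamine B assay, with a stated time of 48 h (a higher number here means a weaker inhibitor, a lower number a stronger inhibitor), compound 1 gives 33300 nM. For compound 2 this assay reports only a limit, > 100000 nM (the limit of > 100000 nM in this assay, at which 1 of the 2 values shown sits), so compound 2 stands at the weak end of the two numbers shown. Among the measured compounds shown here, the one step measured, an at least 3.0-fold higher number from compound 1 to compound 2 (0.47 log units; beyond the scatter), went in the weakening direction. Compound 3 `COc1ccc(/C=C2\C(=O)N(Cc3cn([C@@H]4O[C@H](COC(C)=O)[C@@H](OC(C)=O)[C@H](OC(C)=O)[C@H]4OC(C)=O)nn3)c3ccccc32)cc1OC` differs from compound 2 by 3,4-dimethoxyphenyl in place of 4-methylphenyl on a double-bonded chain carbon bound to a double-bonded ring carbon. For the measured compounds named here, no measured step swaps one aromatic substituent for another, so the single step that exists does not speak directly to this change; it shows only that altering this ring once weakened inhibition beyond the scatter. With compound 2 already at the limit, the number for compound 3 is expected to move by no more than the scatter, a number no higher from compound 2 to compound 3 (the limit leaves the size open), in this assay. Compound 3 is estimated at 100000 nM, between 30000 nM and 300000 nM.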

Compound 3, half-maximal inhibitory concentration: 63400 nM
Estimate against measurement, compound 3: 1.6-fold (0.20 log units) above, within the range that was stated.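

In this assay, 3,4-dimethoxyphenyl in place of phenyl gives a 1.9-fold higher number from compound 1 to compound 3 (0.28 log units; within the scatter), so adding groups to this ring at this position does not always produce the clear weakening seen with 4-methylphenyl. Set against 4-methylphenyl itself, the change gives an at least 1.5-fold lower number from compound 2 to compound 3 (0.19 log units; that floor lies within the scatter), which leaves the true size of this step unknown and does not establish a difference beyond the scatter. The reading for compound 2 is only a limit: the limit of > 100000 nM in this assay, at which 1 of the 3 values shown sits.

The compounds shown leave open whether a different group on this ring, such as an amine or a carboxylic acid, would move the number beyond the scatter in either direction. They also leave open whether a single methoxy group would match phenyl or 3,4-dimethoxyphenyl.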